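Series notes: cytotoxicity after removing the methoxy group

This account rests on a few compounds, and the source may have more. Where it says the series, first, only, none or still open, it means among the compounds named here.

Measured compounds in an ADME assay on MT4 cells (Homo sapiens) for cytotoxicity; on this read-out lower numbers stand for higher toxicity in this test and higher numbers for lower toxicity in this test:
compound 1, `COc1ccc(-c2nnsc2SCC(=O)Nc2ccc(C)cc2Br)cc1`, 249000 nM
compound 2, `COC(=O)c1ccc(NC(=O)CSc2snnc2-c2ccc(OC)cc2)c(Br)c1`, 195000 nM
compound 3, `CCOC(=O)c1ccc(NC(=O)CSc2snnc2-c2ccc(OC)cc2)c(Br)c1`, value reported only as a limit

The value of compound 3 is a limit, not a number: compound 3 gives > 245000 nM in this assay. Among the readable numbers compound 2 stands lowest, with compound 1 nearest, and that gap, a 1.3-fold lower number from compound 1 to compound 2 (0.11 log units; within the scatter), lies within the scatter. The step of an at least 1.2-fold higher number from compound 2 to compound 3 (0.09 log units; that floor lies within the scatter) is a floor that also lies within the scatter, and a step that the limit leaves unreadable from compound 1 to compound 3 cannot be read, as the limit of > 245000 nM in this assay, at which 1 of the 3 values shown sits, shows.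

Compound 4, `COC(=O)c1ccc(NC(=O)CSc2snnc2-c2ccccc2)c(Br)c1`, is not yet measured. It differs from compound 2 in one place: hydrogen in place of methoxy on an aromatic carbon.

Among the compounds with values here, none of the measured steps touches this ring; they all concern the substituent on the amide-bearing ring, and none of them exceeds the scatter. Within the data shown here, there is thus no measured step that bears directly on the methoxy removal, and nothing shows a change beyond the scatter in this assay.

The expected step of a 1.0-fold higher number from compound 2 to compound 4 (0.01 log units; within the scatter) is therefore no change beyond the scatter. Compound 4 is estimated at 200000 nM, with a range from 90000 nM to 400000 nM.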

Compound 4, half-maximal cytotoxic concentration: > 269000 nM
Compound 4 gave a limit, no number; the forecaster's own chance of this, stated with the estimate: 35%; at least 1.3-fold (0.12 log units) between middle value and limit.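

In this assay, within the data shown here, the change from 4-methoxyphenyl to phenyl gives the only measured step on this ring, at an aromatic carbon para to a large group: an at least 1.3-fold higher number from compound 2 to compound 4 (0.13 log units; that floor lies within the scatter). Compound 4 is reported only as a limit: the limit of > 269000 nM in this assay, at which 1 of the 4 values shown sits. Among these compounds, the earlier steps all concerned the substituent on the amide-bearing ring, so this is the first evidence on the methoxy group itself: taking it out gives no sign of a lower number in this test, although the floor of the step stays within the scatter and its full size cannot be read.

From the compounds shown here alone, what remains open is whether an amine, a carboxylic acid or a longer alkoxy chain in place of methoxy at this carbon would move the number beyond the scatter in this assay. Also open, going by these compounds, is how the phenyl compound would read with ethoxycarbonyl or methyl in place of methoxycarbonyl on the amide-bearing ring, since a limit on compound 4 gives no number against which to set such a change.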